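Dichloroacetamides on a biaryl core

The source may report more compounds than this note shows. Statements on the series, on what has been measured and on what is new or still open speak of the compounds shown alone.

Measured so far:
compound 1, `O=C(Nc1cccc(-c2ccc(F)cc2)c1)C(Cl)Cl`, > 50000 nM
compound 2, `O=C(Nc1cccc(-c2cccc(F)c2)c1)C(Cl)Cl`, > 50000 nM

In a functional assay on NCI-H460 cells (Homo sapiens) for cytotoxicity, read by MTT assay, with a stated time of 68 h (on this read-out lower numbers stand for stronger inhibition and higher numbers for weaker inhibition), compound 1 gives only a limit, > 50000 nM. Compound 2 likewise reaches only a limit in this assay, > 50000 nM. Both values sit at the limit of > 50000 nM in this assay, at which 2 of the 2 values shown sit. Compound 2 therefore stands at the limit, with no measurable number in the series to set it against. Compound 3, `COc1cccc(-c2cccc(NC(=O)C(Cl)Cl)c2)c1`, differs from compound 2 by methoxy in place of fluoro on an aromatic carbon. Within the data shown here, with no measured step in hand and both values at the limit, no change beyond the usual scatter is expected in this assay. Compound 3 is thus estimated at 60000 nM, range 20000 nM to 200000 nM. The expected step is a step that the limit leaves unreadable from compound 2 to compound 3.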

Compound 3, half-maximal inhibitory concentration: 33800 nM
Beside the measured number, compound 3's estimate is 1.8-fold (0.25 log units) above it; measured number inside the range.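

Methoxy in place of fluoro on an aromatic carbon, meta to a large group, gives the only measured number so far in this assay, with an at least 1.4-fold lower number from compound 2 to compound 3 (0.17 log units; that floor lies within the scatter). Compound 2 gives only a limit, and the true size of the change stays unread. The other values shown remain at that limit: the limit of > 50000 nM in this assay, at which 2 of the 3 values shown sit.

From the compounds shown here alone, whether an amine or a longer chain such as ethoxy at this position would give a number clearly beyond the scatter stays open.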